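Moving two fluorines on the benzyl group of a shared core

A few compounds are considered here, and "the series" means these few. Any claim that something is new, unique, unknown or untested is made for them only; others in the source may bear on it.

Measured compounds:
compound 1, `COc1ccc2[nH]c3c(c2c1)CCNC31CCN(Cc2ccccc2)CC1`, 12600 nM
compound 2, `COc1ccc2[nH]c3c(c2c1)CCNC31CCN(Cc2cc(F)cc(F)c2)CC1`, 11100 nM

Both compounds were measured in an assay on FRT cells for positive allosteric modulation of Cystic fibrosis transmembrane conductance regulator variant N1303K (Homo sapiens), in the presence of a further agent that is not named here; on this read-out lower numbers stand for an effect already at smaller amounts and higher numbers for an effect only at larger amounts of compound. Within the data shown here, compound 2 stands level with compound 1 there: the only step so far, a 1.1-fold lower number from compound 1 to compound 2 (0.06 log units; within the scatter), is within the scatter, so the two numbers cannot be told apart. Compound 3, `COc1ccc2[nH]c3c(c2c1)CCNC31CCN(Cc2cccc(F)c2F)CC1`, has not yet been measured. It differs from compound 2 by 2,3-difluorophenyl in place of 3,5-difluorophenyl on a saturated chain carbon bound to an amine nitrogen in a ring. Among the measured compounds shown here, the only measured step that bears on this change is a 1.1-fold lower number from compound 1 to compound 2 (0.06 log units; within the scatter), which added two fluorines to the phenyl without moving the number beyond the scatter. Nothing measured here shows that the placement of the two fluorines on that ring matters, so no step beyond the scatter is expected in this assay. Compound 3 is therefore expected to give 11000 nM, in a range from 4500 nM to 27000 nM. The expected step is a 1.0-fold lower number from compound 2 to compound 3 (0.00 log units; within the scatter).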

Compound 3, half-maximal effective concentration: 13600 nM
Compound 3: middle estimate off by 1.2-fold (0.09 log units), on the low side, within the range that was stated.
By their numbers in this assay, from the lowest: compounds 2, 1 and 3 (each within the scatter of the next).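

In this assay, moving the two fluorines from the 3,5-difluorophenyl to the 2,3-difluorophenyl arrangement, on a saturated chain carbon bound to an amine nitrogen in a ring, gives a 1.2-fold higher number from compound 2 to compound 3 (0.09 log units; within the scatter) and so stays within the scatter, which means these two placements cannot be told apart. Measured against the plain phenyl of compound 1, the new arrangement gives a 1.1-fold higher number from compound 1 to compound 3 (0.03 log units; within the scatter) and also stays within the scatter, so compound 3, like compound 2, cannot be separated from compound 1 on this read-out. No measurement at hand offers an explanation for this result.

The compounds shown leave open whether a different group on this phenyl, such as a methoxy, a nitrile or a carboxylic acid, would bring a step beyond the scatter. As far as these compounds go, it also remains open whether a longer chain between the phenyl and the amine nitrogen would do so.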